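Amide variation across three analogues

This account rests on a few compounds, and the source may have more. Where it says the series, first, only, none or still open, it means among the compounds named here.

Measured compounds, with their values in a functional assay on the whole organism (strain Swiss albino) for inhibition, with Mus musculus as the target, in the writhing test, with stated times of 60 min and 15 min, at a dose of 100 mg/kg by the oral route; a higher number here means more inhibition at the dose given (going by the name of the read-out), a lower number less inhibition:
compound 1 `COc1cc2c(cc1OC)C(CC(=O)NCc1ccccc1)CC2` gives 48.1%
compound 2 `COc1cc2c(cc1OC)C(CC(=O)N1CCCCC1)CC2` gives 44.7%

Among the compounds with values here, compound 2 stands as the lower of the two numbers, though the one known step, a number 3.4 percentage points lower from compound 1 to compound 2 (within the scatter), lies within the scatter. Compound 3 `COc1cc2c(cc1OC)C(CC(=O)N1CCOCC1)CC2` differs from compound 2 by morpholin-4-yl in place of piperidin-1-yl on a carbonyl carbon. Within the data shown here, no measured step exchanges piperidin-1-yl for morpholin-4-yl; the only step at the carbonyl carbon stayed within the scatter, so nothing beyond the scatter is expected in this assay, and the expected step is a number 2.7 percentage points lower from compound 2 to compound 3 (within the scatter). Compound 3 is estimated at 42%, between 28% and 56%.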

Compound 3, a percentage reported as inhibition, in the whole organism at one dose (the size of the read-out at that dose, not a potency): 23.6%
Beside the measured number, compound 3's estimate is 18.4 percentage points above it; measured number below the stated range.
By their numbers in this assay, from the lowest: compound 3; then compounds 2 and 1 (each within the scatter of the next).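

In this assay, the group on the carbonyl carbon now matters, a change the earlier step within the scatter did not show: the series gives a drop (a number 21.1 percentage points lower from compound 2 to compound 3 (beyond the scatter)) and a second drop (a number 24.5 percentage points lower from compound 1 to compound 3 (beyond the scatter)). Morpholin-4-yl keeps the six-membered non-aromatic ring of piperidin-1-yl but has 2 hetero atoms and 1 hydrogen-bond acceptor. Nothing available explains the drop.

Whether the ring oxygen alone accounts for it stays open. Thiomorpholine or N-methylpiperazine amides would test whether other ring hetero atoms follow compound 3 or compound 2.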